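Compound 1 and its form without a drawn configuration

The compounds below may be only part of what the source reports. "The series", "measured", "known", "first", "only" and "open" are said of these compounds alone.

For the measured compounds named here, in a functional assay on T98G cells (Homo sapiens) for cytotoxicity, read by MTT assay, with a stated time of 48 h (on this read-out lower numbers stand for stronger inhibition and higher numbers for weaker inhibition), compound 1 `C/C(=N\NC(=S)Nc1ccccc1I)c1ccccn1` gives 8.09 nM, the higher of the two numbers measured so far. Going by the values given here, the only other measured compound is compound 2 `C/C(=N\NC(=S)Nc1ccccc1Cl)c1ccccn1`, which gives 1.1 nM. Among the compounds with values here, the single measured step, a 7.4-fold lower number from compound 1 to compound 2 (0.87 log units; beyond the scatter), is chloro in place of iodo on an aromatic carbon, and it lies beyond the scatter.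

The next compound is compound 3 `CC(=NNC(=S)Nc1ccccc1I)c1ccccn1`, and its difference is the two compounds have the same atoms and bonds; at least one stereo element is drawn with a configuration in one of them and without one in the other: 1 of 1 stereo elements differ; a double bond is drawn E in compound 1 and without a configuration in compound 3. The atoms and bonds are the same, and the double bond is simply drawn without a configuration. Within the data shown here, the halogen step does not bear directly on this comparison, since no halogen changes here, and no measured step covers a change in drawn configuration. The data also do not show which configuration is present in the sample of compound 3. No step beyond the scatter is therefore expected in this assay, and compound 3 should stay close to compound 1 at 8.09 nM. The estimated change is a 1.0-fold lower number from compound 1 to compound 3 (0.00 log units; within the scatter), and either direction remains possible within the expected range. For compound 3 the estimated value is 8 nM, with an expected range of 3.5 nM to 18 nM.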

Compound 3, half-maximal inhibitory concentration: 8.1 nM
Estimate against measurement, compound 3: 1.0-fold (0.01 log units) below; the measured number falls inside the stated range.
By their numbers in this assay, from the lowest: compound 2; then compounds 1 and 3 (each within the scatter of the next).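

In this assay, removing the drawn configuration from the double bond leaves the read-out within the scatter: a 1.0-fold higher number from compound 1 to compound 3 (0.00 log units; within the scatter). For the compounds shown here, the earlier step concerned only the halogen on an aromatic carbon, whereas this pair gives the first reading at the double bond and shows that, for the iodo compounds, the number does not depend on whether an E configuration is drawn. This does not establish that configuration is unimportant, as the sample of compound 3 may hold the same form as compound 1, and the only recorded difference within the pair is one of depiction: the fact that one of compounds 1 and 3 is drawn with a defined configuration and the other without, at the place where they differ

The compounds shown leave open how a double bond drawn Z would read in this assay, and whether a chloro compound without a drawn configuration would stay as close to compound 2 as compound 3 does to compound 1. They also leave open how far the halogen result extends, for example whether a fluoro, methoxy or amine group in place of the iodo or chloro group would give a number nearer to that of compound 2 or to that of compound 1.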